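The compounds below may be only part of what the source reports. "The series", "measured", "known", "first", "only" and "open" are said of these compounds alone.

Measured in a functional assay on L1210 cells (Mus musculus) for antiproliferative activity, read by cell counting, with a stated time of 96 h; on this read-out lower numbers stand for stronger inhibition and higher numbers for weaker inhibition:
- compound 1 `CC(Nc1ccccc1Oc1cccc(F)c1)=C1C(=O)CC(c2ccccc2)CC1=O`: 330 nM
- compound 2 `CC(Nc1ccccc1Oc1ccccc1)=C1C(=O)CC(c2ccccc2)CC1=O`: 86 nM
- compound 3 `CC(Nc1ccccc1Oc1ccc(N)cc1)=C1C(=O)CC(c2ccccc2)CC1=O`: 40 nM

Compound 3 has the lowest number of the three, and its steps to both others lie beyond the scatter. Compound 4 `COc1cccc(Oc2ccccc2NC(C)=C2C(=O)CC(c3ccccc3)CC2=O)c1`, not yet measured, places 3-methoxyphenyl in place of 4-aminophenyl on an oxygen on an aromatic ring.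

Three modest steps bear on this: a 2.2-fold lower number from compound 2 to compound 3 (0.33 log units; beyond the scatter), an 8.3-fold lower number from compound 1 to compound 3 (0.92 log units; beyond the scatter) and a 3.8-fold lower number from compound 1 to compound 2 (0.58 log units; beyond the scatter). Compound 4 lacks the amino group, and its 3-methoxyphenyl has the closest named counterpart in the 3-fluorophenyl of compound 1 at 330 nM. A modest move to a higher number is therefore expected, namely a 3.5-fold higher number from compound 3 to compound 4 (0.54 log units; beyond the scatter). Compound 4 is estimated at 140 nM, with an expected range of 50 nM to 400 nM.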

Compound 4, half-maximal inhibitory concentration: 58 nM
For compound 4 the middle estimate is 2.4-fold (0.38 log units) above the measured one, within the range that was stated.
By their numbers in this assay, from the lowest: compounds 3, 4 and 2 (each within the scatter of the next, the first and the last beyond it); then compound 1.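

In this assay, 3-methoxyphenyl in place of 4-aminophenyl on an oxygen on an aromatic ring gives a step within the scatter (a 1.5-fold higher number from compound 3 to compound 4 (0.16 log units; within the scatter)), so at this place a group with no hydrogen-bond donor matches the 4-aminophenyl of compound 3. Methoxy in place of hydrogen is also within the scatter (a 1.5-fold lower number from compound 2 to compound 4 (0.17 log units; within the scatter)), whereas methoxy in place of fluoro lies beyond it (a 5.7-fold lower number from compound 1 to compound 4 (0.76 log units; beyond the scatter)), leaving compound 1 as the only one of the four set apart. No evidence shown accounts for these differences.

The compounds shown leave open whether a hydroxy group, a carboxylic acid or a dimethylamino group on this ring would fall with the amino and methoxy compounds or with the fluoro compound. They also leave open whether amino and methoxy would keep these numbers if they exchanged places on the ring.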